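A few compounds are considered here, and "the series" means these few. Any claim that something is new, unique, unknown or untested is made for them only; others in the source may bear on it.

Compound 1 `C=CCn1c(=O)/c(=C\c2ccccc2Cl)[nH]c(=O)/c1=C\c1ccccc1OC`: 2500 nM
Compound 2 `C=CCn1c(=O)/c(=C\c2cc(Br)ccc2F)[nH]c(=O)/c1=C\c1ccccc1OC`: 5100 nM
Compound 3 `C=CCn1c(=O)/c(=C\c2cccc(Br)c2)[nH]c(=O)/c1=C\c1ccccc1OC`: 2400 nM

In a functional assay on K562 cells (Homo sapiens) for cytotoxicity, read by CCK-8 assay, with a stated time of 72 h (on this read-out higher numbers stand for weaker inhibition and lower numbers for stronger inhibition), compound 3 gives 2400 nM, the lowest of the three numbers, though compound 1 at 2500 nM lies within the scatter of it; only compound 2 at 5100 nM sits clearly apart, by a 2.1-fold lower number from compound 2 to compound 3 (0.33 log units; beyond the scatter). Compound 4 `C=CCn1c(=O)/c(=C\c2cc(F)ccc2C)[nH]c(=O)/c1=C\c1ccccc1OC` differs from compound 3 by 5-fluoro-2-methylphenyl in place of 3-bromophenyl on a double-bonded chain carbon bound to an aromatic carbon. Among the measured compounds shown here, two measured steps bear on this: a 2.0-fold higher number from compound 1 to compound 2 (0.31 log units; beyond the scatter), where the doubly substituted 5-bromo-2-fluorophenyl gave a modest rise, and a 2.1-fold lower number from compound 2 to compound 3 (0.33 log units; beyond the scatter), where the 3-bromophenyl brought the number back down. Since the 5-fluoro-2-methylphenyl of compound 4 likewise carries two substituents, a modest rise in this assay is expected, a 1.7-fold higher number from compound 3 to compound 4 (0.22 log units; within the scatter). Compound 4 is therefore estimated at 4000 nM, ranging from 2000 nM to 8000 nM.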

Compound 4, half-maximal inhibitory concentration: 1800 nM
Compound 4: the middle estimate sits 2.2-fold (0.35 log units) above what was measured; measured number below the stated range.
By their numbers in this assay, from the lowest: compounds 4, 3 and 1 (each within the scatter of the next); then compound 2.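

In this assay, carrying two substituents on this aromatic ring does not by itself raise the number at this position: 5-fluoro-2-methylphenyl shows a 1.3-fold lower number from compound 3 to compound 4 (0.12 log units; within the scatter) and a 1.4-fold lower number from compound 1 to compound 4 (0.14 log units; within the scatter) against groups with one substituent. The earlier rise thus goes with 5-bromo-2-fluorophenyl in particular and not with every doubly substituted ring, as a 2.8-fold lower number from compound 2 to compound 4 (0.45 log units; beyond the scatter) shows. No measurement given here explains this difference.

The compounds shown leave open whether the methyl or the fluoro matters more in compound 4, and how an amine or a carboxylic acid on this ring would read.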